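Trifluoromethyl for fluoro on the aniline ring of compound 3

The source may hold more compounds than are shown below. What is called first, only, known or untested is meant among the compounds shown, and "the series" means these compounds.

Measured compounds:
compound 1 `O=C(/C=C\Nc1ccc(F)cc1)c1cn(-c2ccccc2)nc1-c1ccccc1` 10200 nM
compound 2 `COc1cc(N/C=C\C(=O)c2cn(-c3ccccc3)nc2-c2ccccc2)cc(OC)c1OC` 2350 nM
compound 3 `O=C(/C=C\Nc1ccc(F)cc1)c1cn(-c2ccccc2)nc1-c1ccc(F)cc1` 18200 nM

In a functional assay on U-87MG ATCC cells (Homo sapiens) for antiproliferative activity, read by MTT assay, with a stated time of 48 h (a higher number here means a weaker inhibitor, a lower number a stronger inhibitor), compound 3 gives the highest of the three numbers. Its nearest neighbour is compound 1; the step of a 1.8-fold higher number from compound 1 to compound 3 (0.25 log units; within the scatter) lies within the scatter, so the two cannot be ordered. Among the compounds with values here, compound 2 sits furthest away with 2350 nM, a gap beyond the scatter, but compound 2 differs from compound 3 in more than one place and no single step connects them.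

Compound 4 `O=C(/C=C\Nc1ccc(C(F)(F)F)cc1)c1cn(-c2ccccc2)nc1-c1ccc(F)cc1` carries the change (trifluoromethyl in place of fluoro on an aromatic carbon). Within the data shown here, the only measured step, from compound 1 to compound 3, concerns the other aryl ring and was within the scatter; no measured step touches the ring that carries the aniline substituent at the position changed here. There is therefore no basis in the numbers for expecting a step beyond the scatter in this assay in either direction for compound 4.

Compound 4 is expected at 15000 nM, within 6000 nM to 40000 nM. This estimate means a step of a 1.2-fold lower number from compound 3 to compound 4 (0.08 log units; within the scatter) that is expected to stay within the scatter.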

Compound 4, half-maximal inhibitory concentration: > 50000 nM
Compound 4 gave a limit, no number (the forecaster's own chance of this, stated with the estimate: 20%); middle value at least 3.3-fold (0.52 log units) from the limit.
By their numbers in this assay, from the lowest: compound 2; then compounds 1 and 3 (each within the scatter of the next). At a limit, above all of these: compound 4.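

In this assay, trifluoromethyl in place of fluoro on the aromatic carbon para to a large group gives an at least 2.7-fold higher number from compound 3 to compound 4 (0.43 log units; beyond the scatter). Compound 4 stands at > 50000 nM, which is a limit of the assay and not a number. The only earlier one-place step, a 1.8-fold higher number from compound 1 to compound 3 (0.25 log units; within the scatter), concerns the other aryl ring and stays within the scatter, so this aniline-ring position is the first place in the series where a single change moves the number beyond the scatter, though the size of that step is known only from one side: the limit of > 50000 nM in this assay, at which 1 of the 4 values shown sits.

Only fluoro and trifluoromethyl can be compared directly at this carbon, which leaves open how the number responds there to a group of another kind, such as an amine, a nitrile or a carboxylic acid. As far as these compounds go, it also remains open whether the same change would give a step of similar size on the core of compound 1, which has no fluoro on the other aryl ring.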